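The source may report more compounds than this note shows. Statements on the series, on what has been measured and on what is new or still open speak of the compounds shown alone.

Measured so far:
- Compound 1, `COc1cccc(CNCCCNc2ccnc3cc(Oc4ccc(Cl)cc4)ccc23)c1O`: 9.28 in a physicochemical assay for acid dissociation
- Compound 2, `COc1ccc(F)cc1CNCCCNc1ccnc2cc(CCC(C)C)ccc12`: 9.47 in this assay
- Compound 3, `COc1ccc(F)cc1CNCCCNc1ccnc2cc(CCc3ccccc3)ccc12`: 9.47 in this assay

Compound 3 stands level with compound 2 at the digits shown, and these two together are the highest of the three numbers. Compound 1 sits somewhat lower, but that gap is within the usual scatter, so the three values lie within one cluster. Among the compounds with values here, the single step measured so far, no change at the digits printed from compound 2 to compound 3 (within the scatter), exchanged one group for another on the chain that hangs off the shared core and left the value untouched.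

Compound 4, `COc1ccc(F)cc1CNCCCNc1ccnc2cc(Cc3ccc(C#N)cc3)ccc12`, differs from compound 3 in the same region: 4-cyanophenyl in place of benzyl on a saturated chain carbon bound to an aromatic carbon. Within the data shown here, the only step that bears on this is the one from compound 2 to compound 3, which altered the same chain and gave no change beyond the scatter. On that basis no shift beyond the scatter is expected either, so a number 0.02 log units lower from compound 3 to compound 4 (within the scatter) is the expected step. Compound 4 is therefore estimated at 9.45, with a range from 9.2 to 9.7.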

Compound 4, acid dissociation constant: 9.47
Compound 4: the middle estimate sits 0.02 log units below what was measured; low and high end bracket the measured number.
By their numbers in this assay, from the lowest: compounds 1, 2, 3 and 4 (each within the scatter of the next).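

In this assay, the new group brings a nitrile, with a nitrogen and a hydrogen-bond acceptor that benzyl lacks, yet the swap gives no change at the digits printed from compound 3 to compound 4 (within the scatter). Set against the isobutyl group, 4-cyanophenyl likewise gives no change at the digits printed from compound 2 to compound 4 (within the scatter). Compounds 2, 3 and 4 therefore show that, among these groups, neither an aromatic ring nor a nitrile on that ring moves the number beyond the scatter, and none of the three goes against this; nothing shown explains why.

How an amine or a carboxylic acid at this place would read remains open, since all the groups shown here lack both. As far as these compounds go, compound 1 differs from the others in more than one place, so the effect of its separate changes also remains open.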